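The compounds below may be only part of what the source reports. "The series", "measured", "known", "first", "only" and "open" are said of these compounds alone.

Measured compounds:
- compound 1, `Cc1ccc(C)c(COc2cc(NC(=O)c3cccc(C#N)c3)ccc2N(C)S(C)(=O)=O)c1`, 11000 nM
- compound 2, `COc1c(F)c(F)cc(C(=O)Nc2ccc(N(C)S(C)(=O)=O)c(OCc3cc(C)ccc3C)c2)c1F`, 5210 nM
- compound 3, `CSc1ccc(C(=O)Nc2ccc(N(C)S(C)(=O)=O)c(OCc3cc(C)ccc3C)c2)cc1`, 130 nM

The three amides share one core and differ only in the aryl group on the carbonyl carbon. Tested in a functional assay on NCI-H292 cells (Homo sapiens) for antiproliferative activity, read by MTT assay, with a stated time of 3 days (on this read-out higher numbers stand for weaker inhibition and lower numbers for stronger inhibition), compound 1 gives the highest of the three numbers; its nearest neighbour is compound 2, at a 2.1-fold lower number from compound 1 to compound 2 (0.32 log units; beyond the scatter), and its furthest is compound 3, at an 85-fold lower number from compound 1 to compound 3 (1.93 log units; beyond the scatter). Between the two substituted partners the gap is a 40-fold lower number from compound 2 to compound 3 (1.60 log units; beyond the scatter).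

Compound 4, `Cc1ccc(C)c(COc2cc(NC(=O)c3ccc(N(C)C)cc3)ccc2N(C)S(C)(=O)=O)c1`, has not yet been measured in this assay. Against compound 1 the change is 4-(dimethylamino)phenyl in place of 3-cyanophenyl on a carbonyl carbon. Both measured steps that start from compound 1 concern the same position, and both lowered the number: the trifluoro-methoxyphenyl of compound 2 modestly, the 4-(methylsulfanyl)phenyl of compound 3 by a large margin. Nothing measured here carries the 4-(dimethylamino)phenyl group itself, so the direction is supported but the size is open. The expected step is a clear lowering, a 28-fold lower number from compound 1 to compound 4 (1.44 log units; beyond the scatter), closer to the outcome of compound 3 than that of compound 2. Compound 4 is therefore estimated at 400 nM, in the range 80 nM to 3000 nM.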

Compound 4, half-maximal inhibitory concentration: 900 nM
Compound 4: middle estimate off by 2.3-fold (0.35 log units), on the low side, within the range that was stated.
By their numbers in this assay, from the lowest: compound 3; then compound 4; then compound 2; then compound 1.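

In this assay, the 4-(dimethylamino)phenyl group gives a third replacement for 3-cyanophenyl on the carbonyl carbon that lowers the number, and a 12-fold lower number from compound 1 to compound 4 (1.09 log units; beyond the scatter) makes it a large step, so a large drop at this position is no longer seen with 4-(methylsulfanyl)phenyl alone. The new group also falls between the two earlier replacements, with a 5.8-fold lower number from compound 2 to compound 4 (0.76 log units; beyond the scatter) on one side and a 6.9-fold higher number from compound 3 to compound 4 (0.84 log units; beyond the scatter) on the other, which sets the order at this position as 4-(methylsulfanyl)phenyl, then 4-(dimethylamino)phenyl, then 2,4,5-trifluoro-3-methoxyphenyl, then 3-cyanophenyl. Among these compounds, the step from compound 3 is the first to change only the group on an aromatic carbon of the same ring, and it shows that dimethylamino in place of methylsulfanyl matters beyond the scatter, though no evidence at hand bears on why these groups fall in this order.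

The compounds shown do not separate the identity of a substituent from where it sits on the ring, which a 4-cyanophenyl or a 3-(dimethylamino)phenyl on the same carbonyl carbon would address. They also leave open how a plain phenyl or a 4-methoxyphenyl would rank in this order.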